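Swapping ethoxy for fluoro: tolerance on Vero cells

The compounds below may be only part of what the source reports. "The series", "measured", "known", "first", "only" and "open" are said of these compounds alone.

Measured so far:
compound 1, `CCOc1ccc(-n2c(SC(C)C(=O)Nc3cc(C)cc(C)n3)nc3ccccc32)cc1` — "not determined" (no result reported)
compound 2, `Cc1nnc(NC(=O)C(C)Sc2nc3ccccc3n2-c2ccc(F)cc2)nc1C` — "not determined" (no result reported)
compound 3, `CCOc1ccc(-n2c(SC(C)C(=O)Nc3ncc(Cl)cc3Cl)nc3ccccc32)cc1` — 18500 nM

Of the three compounds made, only compound 3 carries a number in an ADME assay on Vero cells (Chlorocebus sabaeus) for cytotoxicity, read by MTT assay, with a stated time of 24 h; a lower number here means that less compound is tolerated, a higher number that more compound is tolerated. For compound 1 and compound 2 the outcome was not reported, so compound 3 gives 18500 nM and stands alone; there is nothing beside it to rank it against.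

Compound 4, `CC(Sc1nc2ccccc2n1-c1ccc(F)cc1)C(=O)Nc1ncc(Cl)cc1Cl`, is the next one to be tested. It differs from compound 3 in a single place: fluoro in place of ethoxy on an aromatic carbon. Put more simply, a 4-ethoxyphenyl becomes a 4-fluorophenyl on the shared core.

Going by the values given here, no pair of measured compounds shows what such a swap does in this assay, so there is no recorded step to lean on. With that in mind, the expectation is that the step from compound 3 to compound 4 will be small, a 1.1-fold higher number from compound 3 to compound 4 (0.03 log units; within the scatter), and may well stay within the ordinary scatter of this assay in either direction. The estimate for compound 4 in this assay is 20000 nM, with a likely range from 8000 nM to 50000 nM.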

Compound 4, half-maximal cytotoxic concentration: 5900 nM
Compound 4: middle estimate off by 3.4-fold (0.53 log units), on the high side, and the stated range ends above it.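

Going by these compounds alone, this is the first recorded step at this position: in this assay the change from 4-ethoxyphenyl to 4-fluorophenyl gives a 3.1-fold lower number from compound 3 to compound 4 (0.50 log units; beyond the scatter) on the shared core. The position is therefore not indifferent to what sits on it, and here the smaller fluoro goes with less compound being tolerated by the cells. Ethoxy brings three heavy atoms and a hydrogen-bond acceptor while fluoro brings one heavy atom and no acceptor, but no measurement at hand explains the drop.

On these data alone, whether a methoxy group, a chlorine atom or an amine in this place would land nearer compound 3 or compound 4 remains open. So does whether this swap would give a similar step with a different group on the amide nitrogen, since one pair sets no general rule.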